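A Second Chloro Added to the Shared Core

This account rests on a few compounds, and the source may have more. Where it says the series, first, only, none or still open, it means among the compounds named here.

Measured so far:
compound 1, `ClCc1ccc(Cn2cnc3c(Cl)ncnc32)cc1`, 21400 nM in a functional assay on BT-549 cells (Homo sapiens) for cytotoxicity, read by sulforhodamine B assay, with a stated time of 48 h; a higher number here means a weaker inhibitor of growth, a lower number a stronger inhibitor of growth
compound 2, `ClCc1cccc(Cn2cnc3c(Cl)nc(Cl)nc32)c1`, 3230 nM in this assay

Compound 1 gives the higher of the two numbers in this assay, so of the two it is the weaker inhibitor of growth. Going by the values given here, compound 2 differs from it in more than one place, so no single step links the pair; what the two values show is that compound 2 has the lower number, by a gap beyond the scatter.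

Compound 3, `ClCc1ccc(Cn2cnc3c(Cl)nc(Cl)nc32)cc1`, is compound 1 with chloro in place of hydrogen on an aromatic carbon. Among the compounds with values here, no measured pair shows this change alone. Within the data shown here, still, the only compound here that carries this second chloro, compound 2 with 3230 nM, sits well below compound 1, so the step from compound 1 to compound 3 is expected to lower the number beyond the scatter, by about a 4.8-fold lower number from compound 1 to compound 3 (0.68 log units; beyond the scatter). Compound 3 is therefore estimated at 4500 nM, within a range from 1500 nM to 13000 nM.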

Compound 3, concentration for total growth inhibition: 29500 nM
Estimate against measurement, compound 3: 6.6-fold (0.82 log units) below; the whole stated range lies below it.
By their numbers in this assay, from the lowest: compound 2; then compounds 1 and 3 (each within the scatter of the next).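

Chloro in place of hydrogen on this aromatic carbon, between two ring nitrogen atoms, can now be read on its own: in this assay the change gives a 1.4-fold higher number from compound 1 to compound 3 (0.14 log units; within the scatter), so on the core of compound 1 it leaves the number within the scatter. Compound 2 gives 3230 nM and compound 3, with the same chloro, gives 29500 nM, so the lower number of compound 2 cannot be credited to this chloro alone. Nothing shown here offers an explanation for this result.

Going by these compounds, what remains open is whether a different group on this aromatic carbon, such as an amine or a methoxy group, would shift the number beyond the scatter. Going by these compounds alone, it is also open what sets compound 2 apart, as no single step links it to compound 1.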